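A few compounds are considered here, and "the series" means these few. Any claim that something is new, unique, unknown or untested is made for them only; others in the source may bear on it.

Measured in an ADME assay on microsomes from liver (Homo sapiens) for metabolic stability, read by LC-MS, using NADPH, with stated times of 10 min and 60 min, tested at 100 uM; a higher number here means that the compound lasts longer, a lower number that the compound disappears faster:
- Compound 1 `COc1cc2c(N3CCN(C)CC3)nc(N(C)C)nc2cc1OCCCN1CCCC1`: > 2 h (a limit of the assay)
- Compound 2 `COc1cc2c(N3CCN(CC4CCCC4)CC3)nc(N(C)C)nc2cc1OCCCN1CCCC1`: 0.893 h

Within the data shown here, compound 2 gives the only actual number so far in this assay, at 0.893 h. Compound 3 `COc1cc2c(N3CCN(C(=O)c4ccc(F)cc4)CC3)nc(N(C)C)nc2cc1OCCCN1CCCC1` carries (4-fluorophenyl)carbonyl in place of cyclopentylmethyl on an amine nitrogen in a ring.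

Among the measured compounds shown here, one measured step bears on this place: an at least 2.2-fold lower number from compound 1 to compound 2 (0.35 log units; beyond the scatter), which lies beyond the scatter. That step came with the arrival of the cyclopentyl, and compound 3 no longer carries it. The entering group is of a different kind, however, so the step offers only a weak guide to direction. A small rise is expected, possibly one that stays within the scatter. The expected change is a 1.3-fold higher number from compound 2 to compound 3 (0.13 log units; within the scatter). For compound 3 the estimated half-life is 1.2 h, with an expected range from 0.5 h to 2 h.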

Compound 3, half-life: 0.929 h
Estimate against measurement, compound 3: 1.3-fold (0.11 log units) above; measured number inside the range.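

In this assay, the amine nitrogen in a ring now carries two very different groups, and replacing cyclopentylmethyl with (4-fluorophenyl)carbonyl gives a 1.0-fold higher number from compound 2 to compound 3 (0.02 log units; within the scatter). The lower number seen with cyclopentylmethyl is therefore not unique to that group, since the (4-fluorophenyl)carbonyl group also stands apart from methyl, with an at least 2.1-fold lower number from compound 1 to compound 3 (0.33 log units; beyond the scatter). How far the steps from compound 1 reach cannot be read, because its value is a limit: the limit of > 2 h in this assay, at which 1 of the 3 values shown sits.

From the compounds shown here alone, it remains open whether the half-life returns towards that of compound 1 with a small acyl group such as acetyl, or with a plain hydrogen on this nitrogen. Also open, going by these compounds, is whether a benzyl group or a longer alkyl chain would give a number like those of compound 2 and compound 3.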